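This account rests on a few compounds, and the source may have more. Where it says the series, first, only, none or still open, it means among the compounds named here.

Values measured in a functional assay on NCI-H1581 cells (Homo sapiens) for antiproliferative activity, read by CCK-8 assay, with a stated time of 72 h; a lower number here means a stronger inhibitor, a higher number a weaker inhibitor:
- compound 1 `CCN1CCN(c2ccc(C(=O)Nc3n[nH]c4nc(-c5c(Cl)c(OC)cc(OC)c5Cl)ccc34)cc2)CC1`: 0.7 nM
- compound 2 `COc1cc(C(=O)Nc2n[nH]c3nc(-c4c(Cl)c(OC)cc(OC)c4Cl)ccc23)ccc1N1CCN(C)CC1`: 15.6 nM
- compound 3 `COc1cc(OC)c(Cl)c(-c2ccc3c(NC(=O)c4ccc(N5CCN(C)CC5)cn4)n[nH]c3n2)c1Cl`: 4.4 nM

Compound 1 has the lowest number of the three in this assay, so it is the strongest inhibitor here, and its gaps to compound 3 and compound 2 both lie beyond the usual scatter of repeat measurements.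

The next compound, compound 4 `COc1cc(OC)c(Cl)c(-c2ccc3c(NC(=O)c4ccc(N(C)CCN(C)C)cc4)n[nH]c3n2)c1Cl`, keeps the core of compound 1 and changes only the basic side group. It has (2-(dimethylamino)ethyl)(methyl)amino in place of 4-ethylpiperazin-1-yl on an aromatic carbon, para to a large group: (2-(dimethylamino)ethyl)(methyl)amino in place of 4-ethylpiperazin-1-yl on an aromatic carbon. The ring of the old group is thus replaced by an open chain.

For the measured compounds named here, no two measured compounds differ in just one place, and none carries an open chain like this one, so the data offer no direct guide to this swap. Still, compound 1 at 0.7 nM sits at the low end of the measured values, and compound 3 at 4.4 nM and compound 2 at 15.6 nM show that this series can also give higher numbers. A moderate move toward a higher number, meaning a weaker inhibitor, therefore seems more likely than a further drop.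

The estimated change is a 3.6-fold higher number from compound 1 to compound 4 (0.55 log units; beyond the scatter). For compound 4 the expected value is about 2.5 nM, with an estimated range from 0.6 nM to 10 nM.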

Compound 4, half-maximal inhibitory concentration: 11 nM
Compound 4: middle estimate off by 4.4-fold (0.64 log units), on the low side; the whole stated range lies below it.
By their numbers in this assay, from the lowest: compound 1; then compound 3; then compounds 4 and 2 (each within the scatter of the next).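

In this assay, for the compounds shown here, replacing the ring of 4-ethylpiperazin-1-yl with the open chain (2-(dimethylamino)ethyl)(methyl)amino gives a 16-fold higher number from compound 1 to compound 4 (1.20 log units; beyond the scatter), a large step and the first comparison in this set of two compounds that differ in only one place. It shows that the group on this aromatic carbon, para to a large group, cannot be swapped freely, even though both groups have 2 nitrogen atoms, 2 hydrogen-bond acceptors and 0 hydrogen-bond donors, so matching those counts did not keep the inhibitor as strong. Nothing measured here explains why the step is so large.

The swap removes the ring and also changes the groups on the nitrogens, so the compounds shown leave open which of these changes accounts for the weaker inhibition. Also open, as far as these compounds go, is how a morpholin-4-yl ring, or a longer chain, would behave in the same place in this assay.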